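Reading a Substituted Phenyl Swap on Compound 3

The source may report more compounds than this note shows. Statements on the series, on what has been measured and on what is new or still open speak of the compounds shown alone.

Measured in a functional assay on the whole organism with Rattus norvegicus as the target; a higher number here means that more compound is needed for the effect, a lower number that less compound is needed:
Compound 1 `COCCOC(=O)C(=O)Nc1nc(-c2cc(Br)no2)cs1` gives > 100 mg/kg as a limit
Compound 2 `CCOCCOC(=O)C(=O)Nc1nc(-c2cc(-c3ccccc3)on2)cs1` gives 13 mg/kg as a number
Compound 3 `O=C(O)C(=O)Nc1nc(-c2conc2-c2ccccc2)cs1` gives > 100 mg/kg as a limit

Compound 3 has no exact place on this scale, since its result (> 100 mg/kg) is a limit and not a number. This small set shows the limit of > 100 mg/kg in this assay, at which 2 of the 3 values shown sit, as its most common result. Compound 4 `O=C(O)C(=O)Nc1nc(-c2conc2-c2c(F)cccc2Cl)cs1` carries 2-chloro-6-fluorophenyl in place of phenyl on an aromatic carbon. Among the measured compounds shown here, no measured step shows what such a swap does in this assay, so no change beyond the usual scatter is expected in either direction. The expected step is a number no higher from compound 3 to compound 4 (the limit leaves the size open) and it may end at the limit again. Compound 4 is estimated at 100 mg/kg (range 30 mg/kg to 300 mg/kg).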

Compound 4, dose for half-maximal effect: > 100 mg/kg
Compound 4 was reported as a limit; the forecaster's own chance of this, stated with the estimate: 60%; the middle value sits exactly at the limit.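

Compound 3 and compound 4 both gave a limit rather than a number, so no step can be read between them. As far as these compounds go, whether 2-chloro-6-fluorophenyl in place of phenyl changes the dose needed remains open.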